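The source may hold more compounds than are shown below. What is called first, only, known or untested is meant among the compounds shown, and "the series" means these compounds.

Compound 1 `O=C(O)c1cc(-n2cccc2)ccc1O` gives 50 mg/kg in a functional assay on the whole organism for inhibition, with Rattus norvegicus as the target, read by paw edema; on this read-out lower numbers stand for an effect already at smaller amounts and higher numbers for an effect only at larger amounts of compound.
Compound 2 `O=C(O)c1cc(-n2nccn2)ccc1O` gives 150 mg/kg in this assay.

Among the measured compounds shown here, compound 2 holds the highest of the two numbers in this assay; its only neighbour is compound 1, and the step between them is a 3.0-fold higher number from compound 1 to compound 2 (0.48 log units; beyond the scatter). Compound 3 `O=C(O)c1cc(-n2cccn2)ccc1O` differs from compound 2 by 1H-pyrazol-1-yl in place of 2H-1,2,3-triazol-2-yl on an aromatic carbon. For the measured compounds named here, the one measured step that bears on this is a 3.0-fold higher number from compound 1 to compound 2 (0.48 log units; beyond the scatter), where the entering ring carried more ring nitrogens than the leaving one; the pyrazole of compound 3 lies between the pyrrole and the triazole in that respect, so a modest downward step is expected, a 1.7-fold lower number from compound 2 to compound 3 (0.22 log units; within the scatter). Compound 3 is therefore estimated at 90 mg/kg, with a range of 40 mg/kg to 200 mg/kg.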

Compound 3, dose for half-maximal effect: 200 mg/kg
For compound 3 the middle estimate is 2.2-fold (0.35 log units) below the measured one, within the range that was stated.
By their numbers in this assay, from the lowest: compound 1; then compounds 2 and 3 (each within the scatter of the next).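

In this assay, 1H-pyrazol-1-yl in place of 2H-1,2,3-triazol-2-yl gives a 1.3-fold higher number from compound 2 to compound 3 (0.12 log units; within the scatter), so the two rings cannot be told apart at this position. 1H-pyrazol-1-yl in place of 1H-pyrrol-1-yl gives a 4.0-fold higher number from compound 1 to compound 3 (0.60 log units; beyond the scatter), so the clear separation here lies between compound 1 and the other two compounds, not between rings with 2 and 3 hetero atoms. Nothing available explains this difference. The compounds shown leave open how a non-aromatic amine or a simple methoxy group would fare at this position on the shared core.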